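Acetylpyrazolyl in place of phenyl on the anilide cap

The source may hold more compounds than are shown below. What is called first, only, known or untested is meant among the compounds shown, and "the series" means these compounds.

Measured so far in a functional assay on MV4-11 cells (Homo sapiens) for antiproliferative activity, with a stated time of 6 days, tested at 1.56 uM; a higher number here means a stronger effect of the compound at the concentration tested, a lower number a weaker effect:
Compound 1 `CNC(=O)N1CCCc2ccc(NC(=O)c3ccc(-c4ccccc4)cc3)cc21`: 19.7%
Compound 2 `CNC(=O)N1CCCc2ccc(NC(=O)c3cccc(-c4ccn(C)n4)c3)cc21`: 70.5%
Compound 3 `CNC(=O)N1CCCc2ccc(NC(=O)c3cccc(-c4cnn(S(C)(=O)=O)c4)c3)cc21`: 1.6%

Compound 1 stands second highest of the three numbers in this assay. Its nearest neighbour is compound 3, whose inhibition is lower, and the furthest is compound 2, whose inhibition is much higher; both gaps lie beyond the scatter.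

The next compound, compound 4 `CNC(=O)N1CCCc2ccc(NC(=O)c3ccc(-c4cnn(C(C)=O)c4)cc3)cc21`, keeps the shared core and differs from compound 1 in one place: 1-acetyl-1H-pyrazol-4-yl in place of phenyl on an aromatic carbon. The pyrazolyl group enters para to a large group.

Going by the values given here, one measured step bears on this change. a number 68.9 percentage points lower from compound 2 to compound 3 (beyond the scatter): there a pyrazol-4-yl carrying a sulfonyl on its ring nitrogen replaced a methyl-bearing pyrazol-3-yl and the inhibition collapsed. Compound 4 likewise carries a pyrazol-4-yl with an electron-poor acyl group on the ring nitrogen, now entering in place of phenyl. Compound 1 already sits low, so the room for a downward step is limited; the expectation is a modest fall, or no change beyond the scatter, rather than a gain. The estimated step is a number 9.7 percentage points lower from compound 1 to compound 4 (within the scatter).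

For compound 4 the expected inhibition is 10%, within 0% to 35%.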

Compound 4, a percentage reported as inhibition, at one concentration (the size of the read-out at that concentration, not a potency): 23.9%
Compound 4: middle estimate off by 13.9 percentage points, on the low side; the measured number falls inside the stated range.
By their numbers in this assay, from the lowest: compound 3; then compounds 1 and 4 (each within the scatter of the next); then compound 2.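

In this assay, replacing phenyl with 1-acetyl-1H-pyrazol-4-yl para to a large group gives a number 4.2 percentage points higher from compound 1 to compound 4 (within the scatter), so this place accepts the change without a shift beyond the scatter. A five-membered aromatic ring with 2 hetero atoms and 3 hydrogen-bond acceptors thus stands here in place of a carbon-only ring with none, and the read-out stays level; the large fall in a number 68.9 percentage points lower from compound 2 to compound 3 (beyond the scatter), which involved a different pair of groups, does not recur in this step. Nothing measured on these compounds explains why the read-out holds at this place or ties it to any feature of either group.

Still open, going by these compounds, is whether the pyrazole ring or its acetyl group accounts for this result, which a plain 1H-pyrazol-4-yl or a 1-methyl-1H-pyrazol-4-yl on the same cap would help to separate. Also open, on these data alone, is how far this place tolerates other groups on the ring nitrogen, such as a longer acyl chain, a carboxylic acid or an amine, and whether any of them lifts the inhibition clear of the scatter.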